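Diphenylpentyl carbonyl series: replacing the anilide arm

The source may report more compounds than this note shows. Statements on the series, on what has been measured and on what is new or still open speak of the compounds shown alone.

Measured compounds:
compound 1, `O=C(NCCCCC(c1ccc(F)cc1)c1ccc(F)cc1)Nc1ccc(Cl)cc1`: 15 nM in an ADME assay on isolated protein for inhibition of sodium-dependent dopamine transporter (Homo sapiens); on this read-out lower numbers stand for stronger inhibition and higher numbers for weaker inhibition
compound 2, `Cc1cc(Cl)ccc1NC(=O)NCCCCC(c1ccc(F)cc1)c1ccc(F)cc1`: 118 nM in this assay

Compound 2 holds the highest of the two numbers shown. Going by the values given here, its only neighbour is compound 1, and the single measured step, a 7.9-fold higher number from compound 1 to compound 2 (0.90 log units; beyond the scatter), lies beyond the scatter, so the methyl on the aromatic carbon of compound 2 costs a clear amount of inhibition against the shared core.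

Compound 3, `O=C(NCCCCC(c1ccc(F)cc1)c1ccc(F)cc1)c1ccc(Cl)c(C(F)(F)F)c1`, changes the carbonyl-bound arm: 4-chloro-3-(trifluoromethyl)phenyl in place of (4-chloro-2-methylphenyl)amino on a carbonyl carbon. Among the compounds with values here, no measured pair covers this change. Within the data shown here, the one step that bears on it, a 7.9-fold higher number from compound 1 to compound 2 (0.90 log units; beyond the scatter), concerns only the methyl that leaves along with the rest of the (4-chloro-2-methylphenyl)amino group, and in reverse it points toward a lower number. Among the measured compounds shown here, the remainder of the change, from an amino-linked ring to a directly bound ring carrying a trifluoromethyl, has no precedent here, so the expectation is wide.

For compound 3 the estimate in this assay is 30 nM, with a range from 8 nM to 130 nM, which corresponds to an expected step of a 3.9-fold lower number from compound 2 to compound 3 (0.59 log units; beyond the scatter).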

Compound 3, inhibition constant: 603 nM
For compound 3 the middle estimate is 20-fold (1.30 log units) below the measured one, and the stated range ends below it.
By their numbers in this assay, from the lowest: compound 1; then compound 2; then compound 3.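

On this carbonyl carbon, 4-chloro-3-(trifluoromethyl)phenyl in place of (4-chloro-2-methylphenyl)amino gives a 5.1-fold higher number from compound 2 to compound 3 (0.71 log units; beyond the scatter) in this assay, so losing the methyl together with the rest of the arm brings no recovery of inhibition, and compound 3 ends up weaker than the methyl-bearing urea. Measured against the unmethylated arm, the same kind of replacement gives a 40-fold higher number from compound 1 to compound 3 (1.60 log units; beyond the scatter), the largest step in the set, and it shows that this position tolerates a directly bound ring carrying a trifluoromethyl less well than either amino-linked ring, with the leaving groups holding 1 hydrogen-bond donor and the entering group 0. No supporting data bear on why the number rises here.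

From the compounds shown here alone, the step changes the linking nitrogen and the ring substituents together, so the share of each in the loss remains open. A 4-chlorophenyl bound directly to the carbonyl would separate the two, and a methylene in place of the amino nitrogen would test whether the ring needs a one-atom spacer at all.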